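The compounds below may be only part of what the source reports. "The series", "measured", "known", "first", "only" and "open" are said of these compounds alone.

In a functional assay on MGC-803 cells (Homo sapiens) for cytotoxicity, read by MTT assay, with a stated time of 72 h (a lower number here means a stronger inhibitor, a higher number a weaker inhibitor), compound 1 (`CN(C)c1ccc(C=C2C(=O)N(c3ccc(Cl)cc3)N(c3ccc(Cl)cc3)C2=O)cc1`) gives 80200 nM. Compound 2 (`O=C1C(=Cc2ccc(Cl)cc2Cl)C(=O)N(c2ccc(Cl)cc2)N1c1ccc(Cl)cc1`) yields no number in this assay, only a limit: > 128000 nM. That places compound 2 at the limit of > 128000 nM in this assay, at which 1 of the 2 values shown sits.

Compound 3 (`O=C1C(=Cc2ccccc2)C(=O)N(c2ccc(Cl)cc2)N1c1ccc(Cl)cc1`) has not yet been measured. It carries phenyl in place of 2,4-dichlorophenyl on a double-bonded chain carbon bound to a double-bonded ring carbon.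

Within the data shown here, only one measured step bears on this change. It is an at least 1.5-fold higher number from compound 1 to compound 2 (0.20 log units; that floor lies within the scatter), in which 2,4-dichlorophenyl replaces 4-(dimethylamino)phenyl at the same place, and its floor lies within the scatter. Among the measured compounds shown here, no measured step therefore shows a change beyond the scatter at this place, and the phenyl compound has no measured neighbour of its own. No step beyond the scatter is expected in this assay, and compound 3 may well return only a limit too. The estimate corresponds to an at least 1.2-fold lower number from compound 2 to compound 3 (0.10 log units; that floor lies within the scatter), an expected step that stays within the scatter. Compound 3 is estimated at 100000 nM, with an expected range from 45000 nM to 200000 nM.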

Compound 3, half-maximal inhibitory concentration: 27200 nM
Compound 3: the middle estimate sits 3.7-fold (0.57 log units) above what was measured, and the stated range ends above it.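

In this assay, among these compounds, phenyl gives the first change beyond the scatter at this place on the double-bonded chain carbon, with an at least 4.7-fold lower number from compound 2 to compound 3 (0.67 log units; beyond the scatter). The dimethylamino group also proves to matter, since hydrogen in its place on an aromatic carbon gives a 2.9-fold lower number from compound 1 to compound 3 (0.47 log units; beyond the scatter), so both substituted rings shown, 4-(dimethylamino)phenyl and 2,4-dichlorophenyl, give higher numbers than phenyl, and the earlier step between those two alone could not show this. Compound 2 has only a limit, so the step that starts from it is a floor and its full size stays unknown: the limit of > 128000 nM in this assay, at which 1 of the 3 values shown sits.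

From the compounds shown here alone, what remains open is whether any substituent on this ring can bring the number below that of compound 3, or whether a single chlorine, as in 4-chlorophenyl, would already raise it as the 2,4-dichlorophenyl ring does. The compounds shown also leave open how a hydroxyl group, a methoxy group or a carboxylic acid on this ring would compare with phenyl, and they do not place the dimethylamino and dichloro compounds in an order beyond the scatter.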